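A few compounds are considered here, and "the series" means these few. Any claim that something is new, unique, unknown or untested is made for them only; others in the source may bear on it.

Compound 1 `C/C(=C\CC/C(C)=C/CC[C@@H]1[C@@]2(C)CCC(=O)C(C)(C)[C@H]2CC[C@@]1(C)O)CC/C=C(\C)C(=O)OCc1cn(-c2cccc(O)c2)nn1` is the measured starting point: in a functional assay on MDA-MB-231 cells (Homo sapiens) for antiproliferative activity, read by MTT assay, with a stated time of 48 h (on this read-out higher numbers stand for weaker inhibition and lower numbers for stronger inhibition), compound 1 gives 139000 nM. Compound 2 `C/C(=C\CC/C(C)=C/CC[C@@H]1[C@@]2(C)CCC(=O)C(C)(C)[C@H]2CC[C@@]1(C)O)CC/C=C(\C)C(=O)OCc1cn(-c2ccccc2C)nn1` differs from it by 2-methylphenyl in place of 3-hydroxyphenyl on an aromatic nitrogen. For compound 2 the assay reports only a limit, > 150000 nM, so where compound 2 stands is known only as being at or beyond that limit. The step of an at least 1.0-fold higher number from compound 1 to compound 2 (0.03 log units; that floor lies within the scatter) therefore sits at a floor that lies within the scatter, and it is the only measured step that bears on the change now considered; that one of the two values sits at the limit is shown by the limit of > 150000 nM in this assay, at which 1 of the 2 values shown sits. Compound 3 `C/C(=C\CC/C(C)=C/CC[C@@H]1[C@@]2(C)CCC(=O)C(C)(C)[C@H]2CC[C@@]1(C)O)CC/C=C(\C)C(=O)OCc1cn(-c2ccc(C(F)(F)F)cc2)nn1` carries the change (4-(trifluoromethyl)phenyl in place of 2-methylphenyl on an aromatic nitrogen). With both measured compounds already weak and only a floor as guidance, the step that the limit leaves unreadable from compound 2 to compound 3 is expected to stay within the scatter. Compound 3 is accordingly estimated at 160000 nM, with a range from 90000 nM to 300000 nM, and a limit rather than a number is quite likely.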

Compound 3, half-maximal inhibitory concentration: > 150000 nM
Compound 3 was reported as a limit; the forecaster's own chance of this, stated with the estimate: 60%; the middle value is on the limit's open side.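

In this assay compound 3 is reported only as a limit, > 150000 nM, so a second aryl group on this aromatic nitrogen, now 4-(trifluoromethyl)phenyl, gives no number. Setting it in place of the 3-hydroxyphenyl group gives an at least 1.0-fold higher number from compound 1 to compound 3 (0.03 log units; that floor lies within the scatter), so this change shows no separation from compound 1, while the steps between the two compounds reported as limits cannot be read. Only compound 1 has a numerical value in this set, and the other two compounds stand at one shared limit: the limit of > 150000 nM in this assay, at which 2 of the 3 values shown sit.

Going by these compounds, whether a phenyl ring carrying an amine or a carboxylic acid, or a longer alkyl chain in place of the ring, would give a readable value in this assay remains open. For the compounds shown here, also open is whether the hydroxyl group of compound 1 matters, since no close analogue isolates it.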